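Propoxycarbonyl in place of methoxycarbonyl: working notes

This account rests on a few compounds, and the source may have more. Where it says the series, first, only, none or still open, it means among the compounds named here.

Measured so far in a functional assay on HepG2 cells (Homo sapiens) for antiproliferative activity, read by MTT assay, with a stated time of 48 h (on this read-out lower numbers stand for stronger inhibition of growth and higher numbers for weaker inhibition of growth), for two compounds:
- compound 1 `COC(=O)N1N=C(c2ccccc2)CC1c1cc(OC)c(OC)c(OC)c1` gives 3950 nM
- compound 2 `COC(=O)N1N=C(c2cccc(OC)c2)CC1c1cc(OC)c(OC)c(OC)c1` gives 1870 nM

Going by the values given here, compound 2 holds the lower of the two numbers, with compound 1 as its only neighbour. The next structure is compound 3 `CCCOC(=O)N1N=C(c2cccc(OC)c2)CC1c1cc(OC)c(OC)c(OC)c1` and it departs from compound 2 by ethyl in place of hydrogen on a saturated chain carbon bound to an oxygen next to a carbonyl group so that methoxycarbonyl becomes propoxycarbonyl.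

Among the compounds with values here, the one measured step, a 2.1-fold lower number from compound 1 to compound 2 (0.32 log units; beyond the scatter), is methoxy in place of hydrogen on an aromatic carbon. That is a different change at a different place, so it gives no size for this one. With nothing measured at this place, the expectation in this assay rests on compound 2 with 1870 nM as the anchor, and no shift beyond the scatter is expected in either direction. The expected size is a 1.1-fold higher number from compound 2 to compound 3 (0.03 log units; within the scatter) as an estimate that stays within the scatter. The estimate for compound 3 is 2000 nM with 800 nM to 5000 nM as the expected span, kept wide for lack of direct evidence.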

Compound 3, concentration for 50% growth inhibition: > 10000 nM
Compound 3: only a limit was reported; the forecaster's own chance of this, stated with the estimate: 3%; middle value at least 5.0-fold (0.69 log units) away from the limit.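

In this assay compound 3 gives > 10000 nM, which is a limit of the assay and not a number. The change from methoxycarbonyl to propoxycarbonyl carries an at least 5.3-fold higher number from compound 2 to compound 3 (0.72 log units; beyond the scatter), so this place is not indifferent to the chain it bears, and growth inhibition on the core of compound 2 weakens once ethyl enters there, by more than the earlier step on the aromatic carbon, a 2.1-fold lower number from compound 1 to compound 2 (0.32 log units; beyond the scatter), moved the number in the other direction. The new step gives only a lower bound on its size, and the series has a single reading of this kind: the limit of > 10000 nM in this assay, at which 1 of the 3 values shown sits.

The compounds shown leave open whether ethoxycarbonyl, the intermediate chain, already weakens growth inhibition, and whether a branched chain such as isopropoxycarbonyl or a longer chain such as butoxycarbonyl behaves like propoxycarbonyl. They also leave open whether the same change acts alike on the core of compound 1, which lacks the methoxy group on the aromatic carbon, and whether an amine-derived amide in place of the methoxycarbonyl oxygen would be tolerated at this place.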